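Halogenated aryl hydrazones on a shared core

The source may report more compounds than this note shows. Statements on the series, on what has been measured and on what is new or still open speak of the compounds shown alone.

Three compounds share one core and differ only in the aryl group on the carbon with a double bond to nitrogen. In a functional assay on PC-3 cells (Homo sapiens) for antiproliferative activity, read by MTT assay (on this read-out lower numbers stand for stronger inhibition and higher numbers for weaker inhibition), compound 1 `Cn1c(=O)c(=O)n(C2CCCC2)c2nc(N/N=C/c3ccc(S(C)(=O)=O)cc3)ncc21` gives 26600 nM, compound 2 `COc1ccc(/C=N/Nc2ncc3c(n2)n(C2CCCC2)c(=O)c(=O)n3C)cc1` gives 26300 nM, and compound 3 `Cn1c(=O)c(=O)n(C2CCCC2)c2nc(N/N=C/c3ccc(F)cc3Br)ncc21` gives 9250 nM, the lowest of the three numbers. The steps were a 2.9-fold lower number from compound 1 to compound 3 (0.46 log units; beyond the scatter) and a 2.8-fold lower number from compound 2 to compound 3 (0.45 log units; beyond the scatter), while a 1.0-fold lower number from compound 1 to compound 2 (0.00 log units; within the scatter). Compound 4 `Cn1c(=O)c(=O)n(C2CCCC2)c2nc(N/N=C/c3cc([N+](=O)[O-])ccc3Cl)ncc21` carries 2-chloro-5-nitrophenyl in place of 2-bromo-4-fluorophenyl on a carbon with a double bond to nitrogen. Both steps toward compound 3 bear on this exchange of one halogenated ring for another, but they were modest. Compound 4 is therefore expected to stay near compound 3 in this assay, the expected step being a 1.2-fold higher number from compound 3 to compound 4 (0.08 log units; within the scatter). The estimate for compound 4 is 11000 nM, ranging from 4000 nM to 30000 nM.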

Compound 4, half-maximal inhibitory concentration: 9260 nM
Beside the measured number, compound 4's estimate is 1.2-fold (0.07 log units) above it; measured number inside the range.
By their numbers in this assay, from the lowest: compounds 3 and 4 (each within the scatter of the next); then compounds 2 and 1 (each within the scatter of the next).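

In this assay, the exchange of one ring for the other changes nothing beyond the scatter, a 1.0-fold higher number from compound 3 to compound 4 (0.00 log units; within the scatter), even though 2-chloro-5-nitrophenyl shares only a halogen-bearing ring with 2-bromo-4-fluorophenyl. Compound 4 also keeps the gap to the rings without halogen, a 2.8-fold lower number from compound 2 to compound 4 (0.45 log units; beyond the scatter) and a 2.9-fold lower number from compound 1 to compound 4 (0.46 log units; beyond the scatter), so among these four compounds both halogen-bearing rings give the lower numbers, and none goes against this. Nothing available explains this pattern. As far as these compounds go, it remains open whether the chlorine or the nitro group matters more in compound 4, and how a ring carrying an amine or a carboxylic acid would behave on this carbon.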